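Methyl(propyl)amino in place of butylamino on compound 1

The source may report more compounds than this note shows. Statements on the series, on what has been measured and on what is new or still open speak of the compounds shown alone.

In an ADME assay on the whole organism for inhibition, with Echinochloa crus-galli var. formosensis as the target, with a stated time of 4 days (a lower number here means a stronger inhibitor, a higher number a weaker inhibitor), compound 1 (`CCCCNc1nc(Cl)nc(N[C@H](C)c2ccccc2)n1`) gives 38900 nM as the highest of three numbers, beyond the scatter from both of the others. Compound 2 (`CC[C@H](C)Nc1nc(Cl)nc(N[C@@H](C)c2ccccc2)n1`) gives 14100 nM and compound 3 (`C[C@H](Nc1nc(Cl)nc(NC(C)(C)C)n1)c1ccccc1`) gives 7410 nM in the same read-out. Compound 4 (`CCCN(C)c1nc(Cl)nc(N[C@H](C)c2ccccc2)n1`) carries methyl(propyl)amino in place of butylamino on an aromatic carbon and is still unmeasured. Among the measured compounds shown here, the one measured step is a 1.9-fold lower number from compound 2 to compound 3 (0.28 log units; within the scatter) and it concerns a different swap. For the measured compounds named here, no measured pair tests the present change, so no shift beyond the scatter is expected in this assay here. The expected step is a 1.1-fold lower number from compound 1 to compound 4 (0.05 log units; within the scatter) with little to narrow it. The estimate for compound 4 is 35000 nM with an expected range of 12000 nM to 100000 nM for now.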

Compound 4, half-maximal inhibitory concentration: 9770 nM
Beside the measured number, compound 4's estimate is 3.6-fold (0.55 log units) above it, outside the stated range (below it).
By their numbers in this assay, from the lowest: compounds 3, 4 and 2 (each within the scatter of the next); then compound 1.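

In this assay, the swap on the aromatic carbon opposite the ring nitrogen gives a 4.0-fold lower number from compound 1 to compound 4 (0.60 log units; beyond the scatter), so rearranging the same atoms at this position changes the read-out even though the heavy-atom count stays the same. The entering methyl(propyl)amino group has no hydrogen-bond donor, and the number still falls, so a donor on this nitrogen is not required for this level of inhibition. No available measurement accounts for the shift. The compounds shown do not separate the added methyl from the shortened chain, which a methyl(butyl)amino group would test. On these data alone, whether dimethylamino or a piperidine ring at this position would give a lower number remains open.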